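The source may hold more compounds than are shown below. What is called first, only, known or untested is meant among the compounds shown, and "the series" means these compounds.

Of the compounds shown here, three built on one shared core have been tested in a functional assay on HL60/MX2 cells (Homo sapiens) for antiproliferative activity, read by MTT assay, with a stated time of 48 h (a higher number here means a weaker inhibitor, a lower number a stronger inhibitor), and a fourth awaits measurement. Compound 1 `CCN(CC)CCn1c(N)c(-c2nc3ccccc3n2C)c2nc(C#N)c(C#N)nc21` gives 3250 nM in this assay. Compound 2 `CN(C)CCCn1c(N)c(-c2nc3ccccc3n2C)c2nc(C#N)c(C#N)nc21` differs from compound 1 by (dimethylamino)methyl in place of diethylamino on a saturated chain carbon, two bonds along the chain from an aromatic nitrogen. In this assay compound 2 gives 11300 nM, a step of a 3.5-fold higher number from compound 1 to compound 2 (0.54 log units; beyond the scatter). Compound 3 `CCN(CC)CCn1c(N)c(-c2nc3cc(Cl)ccc3[nH]2)c2nc(C#N)c(C#N)nc21` differs from compound 1 by 5-chloro-1H-benzimidazol-2-yl in place of 1-methyl-1H-benzimidazol-2-yl on an aromatic carbon. In this assay compound 3 gives 9290 nM, a step of a 2.9-fold higher number from compound 1 to compound 3 (0.46 log units; beyond the scatter). Between compound 2 and compound 3 no step is broken down here; their two values lie within the usual scatter of each other.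

Compound 4 `CN(C)CCCn1c(N)c(-c2nc3cc(Cl)ccc3[nH]2)c2nc(C#N)c(C#N)nc21` is the one not yet measured. It differs from compound 3 by (dimethylamino)methyl in place of diethylamino on a saturated chain carbon, two bonds along the chain from an aromatic nitrogen. The place of this change reads word for word as in the change from compound 1 to compound 2, so it is the same change, now made on the core of compound 3. Among the measured compounds shown here, the only precedent for it is the step between compound 1 and compound 2, which was a 3.5-fold higher number from compound 1 to compound 2 (0.54 log units; beyond the scatter). On that single precedent a step of like size is expected for compound 4, a 2.8-fold higher number from compound 3 to compound 4 (0.45 log units; beyond the scatter). The expectation is held loosely, since it rests on one pair only. Compound 4 is therefore estimated to give about 26000 nM in this assay, with a likely range from 9000 nM to 70000 nM.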

Compound 4, half-maximal inhibitory concentration: 5310 nM
Beside the measured number, compound 4's estimate is 4.9-fold (0.69 log units) above it, outside the stated range (below it).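

The side-chain change, (dimethylamino)methyl in place of diethylamino, gave a 1.7-fold lower number from compound 3 to compound 4 (0.24 log units; within the scatter) in this assay, a step within the scatter, so what it did on the core of compound 1 did not carry over to the chlorinated core: the same change on two cores in this assay, a 3.5-fold higher number (0.54 log units; beyond the scatter) from compound 1 to compound 2 and a 1.7-fold lower number (0.24 log units; within the scatter) from compound 3 to compound 4, 6.1-fold (0.78 log units) apart, beyond the scatter of two such steps

The exchange of 1-methyl-1H-benzimidazol-2-yl for 5-chloro-1H-benzimidazol-2-yl behaved the same way, giving a 2.1-fold lower number from compound 2 to compound 4 (0.33 log units; beyond the scatter), a modest step that runs the opposite way to the one this exchange gave with the diethylamino chain: the same change on two cores in this assay, a 2.9-fold higher number (0.46 log units; beyond the scatter) from compound 1 to compound 3 and a 2.1-fold lower number (0.33 log units; beyond the scatter) from compound 2 to compound 4, 6.1-fold (0.78 log units) apart, beyond the scatter of two such steps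

This shows that, among these four compounds, the effect of each change depends on what stands at the other place, so a step read on one core cannot simply be added on another; it does not show why this is so, and a single set of four compounds cannot tell whether the same dependence holds across the wider series.

From the compounds shown here alone, whether it would persist with a longer chain such as 4-(dimethylamino)butyl, or with a cyclic amine such as morpholine or piperidine at the chain end, remains open. So does the outcome with other benzimidazole substituents, such as fluoro or methoxy, on either side chain.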